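Trimming the triazole substituent to methyl in a flavanone series

This account rests on a few compounds, and the source may have more. Where it says the series, first, only, none or still open, it means among the compounds named here.

Of the compounds shown here, two of the same core have been measured in a functional assay on RAW264.7 cells (Mus musculus) for inhibition, read by Griess assay, with stated times of 2 h and 24 h; on this read-out higher numbers stand for weaker inhibition and lower numbers for stronger inhibition. Compound 1 `COc1ccc([C@@H]2CC(=O)c3c(O)cc(OCc4cn(Cc5cccc(Cl)c5)nn4)cc3O2)cc1O` gives 18200 nM. Compound 2 `COc1ccc([C@@H]2CC(=O)c3c(O)cc(OCc4cn(C5CCC5)nn4)cc3O2)cc1O` gives 15300 nM, the lowest of the two numbers, with compound 1 nearest at a gap within the scatter. Within the data shown here, the only step recorded so far is a 1.2-fold lower number from compound 1 to compound 2 (0.08 log units; within the scatter).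

Compound 3 `COc1ccc([C@@H]2CC(=O)c3c(O)cc(OCc4cn(C)nn4)cc3O2)cc1O` differs from compound 2 by methyl in place of cyclobutyl on an aromatic nitrogen. Among the measured compounds shown here, the one step that bears on this change is the substituent swap on the same aromatic nitrogen from compound 1 to compound 2, which stayed within the scatter even though a 3-chlorobenzyl group gave way to cyclobutyl. On that basis no step beyond the scatter is expected for compound 3 in this assay, in either direction, though the evidence is thin. Compound 3 is therefore estimated at 17000 nM, with a range from 7000 nM to 40000 nM, meaning an expected step of a 1.1-fold higher number from compound 2 to compound 3 (0.05 log units; within the scatter).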

Compound 3, half-maximal inhibitory concentration: 15200 nM
Beside the measured number, compound 3's estimate is 1.1-fold (0.05 log units) above it; the range from low to high includes it.
By their numbers in this assay, from the lowest: compounds 3, 2 and 1 (each within the scatter of the next).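

In this assay the move to methyl gives a 1.0-fold lower number from compound 2 to compound 3 (0.00 log units; within the scatter) and the full trim from 3-chlorobenzyl gives a 1.2-fold lower number from compound 1 to compound 3 (0.08 log units; within the scatter) with both steps printed as within the scatter. Among these compounds, the earlier pair showed only that one ring-bearing group could replace another on this aromatic nitrogen; compound 3 carries no ring there, just methyl with its 1 heavy atom, and the number still does not leave the scatter. Across these three compounds the read-out therefore does not separate the substituents at this position, and no measurement here accounts for that.

Whether any group on this nitrogen can move the number at all remains open, since an amine, a carboxylic acid or a longer chain is not among the compounds shown. Also open, from the compounds shown here alone, is what the same nitrogen would do with hydrogen in place of methyl.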